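The source may hold more compounds than are shown below. What is called first, only, known or untested is meant among the compounds shown, and "the series" means these compounds.

Compound 1 `O=C(Oc1ccc2ccccc2c1)c1cn(-c2ccccc2)nc1-c1cccnc1` gave "nd(insoluble)" (no result reported); compound 2 `CCc1ccc(OC(=O)c2cn(-c3ccccc3)nc2-c2ccncc2)cc1` gave "nd(insoluble)" (no result reported); compound 3 `CC(C)(C)c1ccc(OC(=O)c2cn(-c3ccccc3)nc2-c2ccncc2)cc1` gave 33300 nM.

Within the data shown here, in a functional assay on Raji cells (Homo sapiens) for cytotoxicity, read by MTT assay, with a stated time of 48 h (on this read-out higher numbers stand for weaker inhibition and lower numbers for stronger inhibition), compound 3 gives 33300 nM, and this is the only number in the set, since compound 1 and compound 2 returned no result. Compound 4 `O=C(Oc1ccc2ccccc2c1)c1cn(-c2ccccc2)nc1-c1ccncc1` is the next member, and it differs from compound 3 by naphthalen-2-yl in place of 4-(tert-butyl)phenyl on an oxygen next to a carbonyl group. Among the measured compounds shown here, no step between two measured compounds is available to anchor this change, so its size is uncertain; the step from compound 3 to compound 4 is expected to stay within the scatter, at a 1.1-fold lower number from compound 3 to compound 4 (0.05 log units; within the scatter), with the wide range reflecting that uncertainty. Compound 4 is therefore estimated at 30000 nM, between 8000 nM and 120000 nM.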

Compound 4, half-maximal inhibitory concentration: 12100 nM
Compound 4: middle estimate off by 2.5-fold (0.39 log units), on the high side; the measured number falls inside the stated range.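

In this assay, naphthalen-2-yl in place of 4-(tert-butyl)phenyl on an oxygen next to a carbonyl group gives a 2.8-fold lower number from compound 3 to compound 4 (0.44 log units; beyond the scatter). Among these compounds, this is the first readable step at this position, and it shows that the number moves although both groups hold 10 heavy atoms, with two six-membered aromatic rings replacing one. Nothing available explains this shift. The compounds shown leave open how a longer chain or an amine on this group would read. Steps involving compound 1 and compound 2 cannot be read, since neither gave a result.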